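A methoxyphenyl in place of a fluorophenyl

The source may hold more compounds than are shown below. What is called first, only, known or untested is meant among the compounds shown, and "the series" means these compounds.

Two measured compounds share one core and differ only in the aryl group on an aromatic nitrogen. Compound 1 `COc1ccc(/C=C\C(=O)O)c(OCc2cn(-c3ccc(NC(C)=O)cc3)nn2)c1CC=C(C)C` carries a 4-acetamidophenyl there, and in a functional assay on T47D cells (Homo sapiens) for cytotoxicity, read by MTT assay, with a stated time of 24 h (on this read-out lower numbers stand for stronger inhibition and higher numbers for weaker inhibition), compound 1 gives 17400 nM. Compound 2 `COc1ccc(/C=C\C(=O)O)c(OCc2cn(-c3ccccc3F)nn2)c1CC=C(C)C` carries a 2-fluorophenyl instead, and in this assay compound 2 gives 11000 nM. The step of a 1.6-fold lower number from compound 1 to compound 2 (0.20 log units; within the scatter) lies within the scatter, so the two numbers cannot be told apart. Among the measured compounds shown here, on the numbers so far compound 2 stands at the lower of the two, with compound 1 as its only neighbour.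

Compound 3 `COc1cccc(-n2cc(COc3c(/C=C\C(=O)O)ccc(OC)c3CC=C(C)C)nn2)c1` makes the change (3-methoxyphenyl in place of 2-fluorophenyl on an aromatic nitrogen). For the measured compounds named here, only the step from compound 1 to compound 2 bears on it, and that step was within the scatter. Going by the values given here, no measured step exchanges one substituent on this phenyl for another at this place, so there is no basis for expecting a move beyond the scatter in this assay. The expected step is a 1.1-fold higher number from compound 2 to compound 3 (0.04 log units; within the scatter). In this assay compound 3 is estimated at 12000 nM, within a range from 5000 nM to 30000 nM.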

Compound 3, half-maximal inhibitory concentration: 20400 nM
For compound 3 the middle estimate is 1.7-fold (0.23 log units) below the measured one; low and high end bracket the measured number.
By their numbers in this assay, from the lowest: compounds 2, 1 and 3 (each within the scatter of the next).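

At this place on the aromatic nitrogen, this assay now covers three aryl groups. Putting 3-methoxyphenyl in place of 2-fluorophenyl gives a 1.9-fold higher number from compound 2 to compound 3 (0.27 log units; within the scatter) and putting it in place of 4-acetamidophenyl gives a 1.2-fold higher number from compound 1 to compound 3 (0.07 log units; within the scatter), so all three compounds remain within the scatter of one another, and the earlier single step could not show this for a methoxy-bearing phenyl, which brings a hydrogen-bond acceptor that 2-fluorophenyl lacks. No accompanying data explain these numbers.

The three aryl groups each carry a different substituent at a different place on the phenyl, so the compounds shown cannot separate the effect of the substituent from that of its place, and a 2-methoxyphenyl or 4-methoxyphenyl would be needed to do so. As far as these compounds go, it also remains open whether a phenyl bearing an amine or a carboxylic acid, or a longer chain in place of the phenyl, would give a step beyond the scatter at this nitrogen.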